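The compounds below may be only part of what the source reports. "The series", "measured", "known", "first", "only" and "open" are said of these compounds alone.

Compound 1, `COC(=O)c1ccc(NC2=CC(=O)c3ncncc3C2=O)cc1`: 2200 nM
Compound 2, `COc1ccc(-c2ccc(NC3=CC(=O)c4ncncc4C3=O)cc2)cc1`: 2100 nM
Compound 3, `CC(=O)c1cccc(NC2=CC(=O)c3ncncc3C2=O)c1`: 2300 nM

All three compounds share one core and differ only in the group attached to the aniline ring. They were tested in a functional assay on MIA PaCa-2 cells (Homo sapiens) for cytotoxicity, read by MTT assay, with a stated time of 72 h (on this read-out lower numbers stand for stronger inhibition and higher numbers for weaker inhibition), where compound 2 gives 2100 nM, the lowest of the three numbers; its gaps to compound 1 and to compound 3 both lie within the scatter, so the three cannot be told apart on this read-out.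

The next compound, compound 4, `NC(=O)c1ccc(NC2=CC(=O)c3ncncc3C2=O)cc1`, has not yet been measured. Compared with compound 2 it carries carbamoyl in place of 4-methoxyphenyl on an aromatic carbon.

Among the measured compounds shown here, one measured step bears on this change, since it swaps the group at the same place: a 1.0-fold lower number from compound 1 to compound 2 (0.02 log units; within the scatter). That swap left the number essentially unchanged. Compound 3, with an acetyl group elsewhere on the ring, gives 2300 nM, again close to the others. Across the three, the choice of group on this ring has so far made no difference beyond the scatter, and the same is expected for the carbamoyl group: the step is estimated as a 1.2-fold higher number from compound 2 to compound 4 (0.08 log units; within the scatter), no more than the scatter.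

Compound 4 is therefore expected to give about 2500 nM in this assay, with a likely range from 1000 nM to 6000 nM.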

Compound 4, half-maximal inhibitory concentration: 8000 nM
For compound 4 the middle estimate is 3.2-fold (0.51 log units) below the measured one, outside the stated range (above it).
By their numbers in this assay, from the lowest: compounds 2, 1 and 3 (each within the scatter of the next); then compound 4.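

The carbamoyl group shows that this place on the aniline ring is not indifferent to what sits there. In this assay, replacing 4-methoxyphenyl gives a 3.8-fold higher number from compound 2 to compound 4 (0.58 log units; beyond the scatter), and amino in place of methoxy on the carbonyl carbon gives a 3.6-fold higher number from compound 1 to compound 4 (0.56 log units; beyond the scatter). Both steps are modest but beyond the scatter, whereas the swap between the two larger groups gave only a 1.0-fold lower number from compound 1 to compound 2 (0.02 log units; within the scatter), so the size of the change in the group does not by itself predict the size of the step: exchanging one group on the carbonyl carbon moved the number, while exchanging methoxycarbonyl for a whole extra ring did not. Nothing measured here accounts for this difference.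

The compounds shown leave open which part of the carbamoyl group goes with the higher number, the amide hydrogen or something else about the group. A carboxylic acid, a nitrile or a methylcarbamoyl group at this same place would help to separate these possibilities, and an amine would show whether the step depends on keeping a carbonyl there at all.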